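Amino Gives Way to Chloro: Compound 3 to Compound 4

The compounds below may be only part of what the source reports. "The series", "measured", "known", "first", "only" and "open" are said of these compounds alone.

Of the compounds shown here, three on one shared core have been measured in a physicochemical assay for solubility, at pH 7.4; on this read-out higher numbers stand for higher solubility and lower numbers for lower solubility. Compound 1 `Cc1cc(NC(=O)Nc2ccc(C)c(Cl)c2)c2ccccc2n1` gives 300 nM, compound 2 `COc1ccc(NC(=O)Nc2cc(C)nc3ccccc23)cc1F` gives 2700 nM, and compound 3 `Cc1cc(NC(=O)Nc2ccc(N)cc2)c2ccccc2n1` gives 18500 nM. Compound 3 stands highest of the three, its gaps to compound 2 and to compound 1 both beyond the usual scatter. Compound 4 `Cc1cc(NC(=O)Nc2ccc(Cl)cc2)c2ccccc2n1` is not yet measured and differs from compound 3 in one place: chloro in place of amino on an aromatic carbon. Going by the values given here, no measured pair shows this same change. Compound 1, which carries chloro and no amino, gives 300 nM, far under compound 3, so a downward step is expected, likely beyond the scatter. The expected step is a 31-fold lower number from compound 3 to compound 4 (1.49 log units; beyond the scatter). Compound 4 is estimated at 600 nM, within a range from 150 nM to 2500 nM.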

Compound 4, solubility: 1400 nM
Beside the measured number, compound 4's estimate is 2.3-fold (0.37 log units) below it; the range from low to high includes it.
By their numbers in this assay, from the lowest: compound 1; then compounds 4 and 2 (each within the scatter of the next); then compound 3.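

In this assay, going by these compounds alone, the change from 4-aminophenyl to 4-chlorophenyl brings a 13-fold lower number from compound 3 to compound 4 (1.12 log units; beyond the scatter) and is the only step here between compounds that differ in one place. It shows that the number responds strongly to which group stands on this aromatic carbon, para to a large group. No measurement shown here bears on what lies behind this step. The compounds shown leave open where a dimethylamino group or a carboxylic acid on the same carbon would fall. They also leave open whether the same change gives a step of similar size when the ring carries a second group.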